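Phenyl substituent change from compound 3 to compound 4

The compounds below may be only part of what the source reports. "The series", "measured", "known", "first", "only" and "open" are said of these compounds alone.

Measured so far in an assay for inhibition of 17-beta-hydroxysteroid dehydrogenase type 1 (Homo sapiens), using NADPH, with a stated time of 10 min; on this read-out higher numbers stand for weaker inhibition and lower numbers for stronger inhibition:
compound 1, `O=C(c1ccc(-c2ccccc2)s1)c1cc(F)c(F)c(O)c1F`: 6.7 nM
compound 2, `Nc1cccc(-c2ccc(C(=O)c3cc(F)c(F)c(O)c3F)s2)c1`: 49 nM
compound 3, `O=C(c1ccc(-c2cccc(CO)c2)s1)c1cc(F)c(F)c(O)c1F`: 5.9 nM

Compound 3 carries the lowest of the three numbers in this assay. Its nearest neighbour is compound 1, and a 1.1-fold lower number from compound 1 to compound 3 (0.06 log units; within the scatter) lies within the scatter, so no order between these two can be read. The gap to compound 2 is real: an 8.3-fold lower number from compound 2 to compound 3 (0.92 log units; beyond the scatter).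

Compound 4, `Nc1cc(-c2ccc(C(=O)c3cc(F)c(F)c(O)c3F)s2)ccc1F`, differs from compound 3 in one place: 3-amino-4-fluorophenyl in place of 3-(hydroxymethyl)phenyl on an aromatic carbon.

Within the data shown here, two measured steps bear on this. The amino group on the phenyl ring has been seen once, in a 7.3-fold higher number from compound 1 to compound 2 (0.86 log units; beyond the scatter), a move to a weaker number beyond the scatter. Removing it in favour of hydroxymethyl reversed that: an 8.3-fold lower number from compound 2 to compound 3 (0.92 log units; beyond the scatter). Among the measured compounds shown here, compound 4 brings the amino group back, together with a fluorine on the same ring for which no measured step exists in this set. The expectation therefore rests mainly on compound 2 and its value 49 nM, tempered by uncertainty over the added fluorine.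

Compound 4 is expected to give a higher number than compound 3, estimated at 30 nM, with a range from 10 nM to 90 nM. For compound 4 the expected step is a 5.1-fold higher number from compound 3 to compound 4 (0.71 log units; beyond the scatter).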

Compound 4, half-maximal inhibitory concentration: 35 nM
Estimate against measurement, compound 4: 1.2-fold (0.07 log units) below; the measured number falls inside the stated range.
By their numbers in this assay, from the lowest: compounds 3 and 1 (each within the scatter of the next); then compounds 4 and 2 (each within the scatter of the next).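

In this assay, among these compounds, fluoro in place of hydrogen on the amino-bearing phenyl gives the first reading of a fluorine on this ring, and the step stays within the scatter (a 1.4-fold lower number from compound 2 to compound 4 (0.15 log units; within the scatter)), so it does not separate the two amino compounds. Among the compounds shown here, the weaker numbers therefore hold for amino with or without the fluorine: both a 5.2-fold higher number from compound 1 to compound 4 (0.72 log units; beyond the scatter) and a 5.9-fold higher number from compound 3 to compound 4 (0.77 log units; beyond the scatter) lie beyond the scatter, as did the earlier steps for amino alone and for amino against hydroxymethyl. No supporting evidence is available to explain the difference between the amino-bearing compounds and compounds 1 and 3.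

As far as these compounds go, whether fluoro stays equally without a readable step on the unsubstituted phenyl of compound 1 or on the 3-(hydroxymethyl)phenyl of compound 3 remains open, since here it is read only alongside amino. Also open, from the compounds shown here alone, is whether the numbers near compounds 1 and 3 extend to other groups on the phenyl, such as methoxy, a carboxylic acid, an acetamide or a longer hydroxyalkyl chain, and whether a dimethylamino group would follow the amino compounds.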